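This account rests on a few compounds, and the source may have more. Where it says the series, first, only, none or still open, it means among the compounds named here.

For the measured compounds named here, compound 1 `O=S(=O)(NCCCCCCNCc1ccc(Br)cc1)c1cc(Cl)cc(Cl)c1` gives 12000 nM in a functional assay on MIA PaCa-2 cells (Homo sapiens) for inhibition, read by MTT assay, with a stated time of 72 h (a lower number here means a stronger inhibitor of growth, a higher number a weaker inhibitor of growth), the second highest of the three numbers so far; compound 2 `CN(CCCNS(=O)(=O)c1cc(C(F)(F)F)cc(C(F)(F)F)c1)Cc1ccccc1` gives 33000 nM and compound 3 `O=S(=O)(NCCCNCc1ccc(Br)cc1)c1cc(C(F)(F)F)cc(C(F)(F)F)c1` gives 2300 nM. Going by the values given here, the only single-point step known, a 14-fold lower number from compound 2 to compound 3 (1.16 log units; beyond the scatter), concerns the amine end of the chain. Compound 4 `Cc1ccc(C)c(S(=O)(=O)NCCCCCCNCc2ccc(Br)cc2)c1` differs from compound 1 by 2,5-dimethylphenyl in place of 3,5-dichlorophenyl on a sulfonyl sulfur. Among the compounds with values here, no measured pair isolates this change at the sulfonyl sulfur; compounds 2 and 3 carry a different sulfonyl aryl but also a different chain, so their values show nothing separable. Within the data shown here, with no bearing step, no move beyond the scatter is expected, and compound 4 is estimated at 12000 nM (range 4000 nM to 40000 nM), a step of no change at the digits printed from compound 1 to compound 4 (within the scatter).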

Compound 4, concentration for 50% growth inhibition: 12000 nM
Compound 4: the middle estimate sits on the measured number at the digits printed, and the stated range covers the measured number.
By their numbers in this assay, from the lowest: compound 3; then compounds 1 and 4 (each within the scatter of the next); then compound 2.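

For the compounds shown here, putting 2,5-dimethylphenyl in place of 3,5-dichlorophenyl on a sulfonyl sulfur gives no change at the digits printed from compound 1 to compound 4 (within the scatter) in this assay, the first reading of a change at this position alone. With the chain and the (4-bromobenzyl)amino end held fixed, this exchange of aryl groups does not separate the two compounds. No evidence on hand bears on this result.

From the compounds shown here alone, an unsubstituted phenyl or a pyridine ring on the sulfonyl sulfur remains open. So does whether the same exchange gives the same outcome on the shorter chain of compound 3.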